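Swapping the Amine a Second Time

The source may report more compounds than this note shows. Statements on the series, on what has been measured and on what is new or still open speak of the compounds shown alone.

Compound 1, `CCN(CC)Cc1cc(Cl)cc2c(=O)cc(-c3ccc([N+](=O)[O-])cc3)oc12`, is the starting point. In a functional assay on SMMC-7721 cells (Homo sapiens) for cytotoxicity, read by MTT assay, with a stated time of 48 h (on this read-out lower numbers stand for stronger inhibition and higher numbers for weaker inhibition), compound 1 gives 2990 nM. Compound 2, `O=c1cc(-c2ccc([N+](=O)[O-])cc2)oc2c(CN3CCCCC3)cc(Cl)cc12`, differs from it by piperidin-1-yl in place of diethylamino on a saturated chain carbon bound to an aromatic carbon, and in this assay compound 2 gives 1090 nM, which is a 2.7-fold lower number from compound 1 to compound 2 (0.44 log units; beyond the scatter). Compound 3, `CCN(CC)Cc1cc(Cl)cc2c(=O)cc(-c3ccccc3Cl)oc12`, keeps the diethylamino group but differs from compound 1 by 2-chlorophenyl in place of 4-nitrophenyl on an aromatic carbon. In this assay compound 3 gives 810 nM, which is a 3.7-fold lower number from compound 1 to compound 3 (0.57 log units; beyond the scatter). The values of compound 3 and compound 2 lie within the scatter of each other, so neither can be called the more active of the two.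

Compound 4, `O=c1cc(-c2ccccc2Cl)oc2c(CN3CCCCC3)cc(Cl)cc12`, has not yet been measured. It differs from compound 3 by piperidin-1-yl in place of diethylamino on a saturated chain carbon bound to an aromatic carbon, the same change that turned compound 1 into compound 2, made this time on the core of compound 3 rather than the core of compound 1. The place of the change is the same in both pairs, so this is the same change on a different core. Going by the values given here, the only guide to its effect is the earlier step. For compound 4 the expectation is a step of a 2.3-fold lower number from compound 3 to compound 4 (0.36 log units; beyond the scatter), roughly the size of that earlier one. That expectation rests on compound 1 and the step of a 2.7-fold lower number from compound 1 to compound 2 (0.44 log units; beyond the scatter) seen on its core, and whether it repeats on a second core is not known from the measured compounds. Compound 4 is therefore estimated at 350 nM in this assay, with a range from 150 nM to 850 nM.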

Compound 4, half-maximal inhibitory concentration: 3400 nM
For compound 4 the middle estimate is 9.7-fold (0.99 log units) below the measured one; measured number above the stated range.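

Carried onto the core of compound 3, the change from diethylamino to piperidin-1-yl in this assay gives a 4.2-fold higher number from compound 3 to compound 4 (0.62 log units; beyond the scatter), so the earlier step did not carry over and instead ran the opposite way: the same change on two cores in this assay, a 2.7-fold lower number (0.44 log units; beyond the scatter) from compound 1 to compound 2 and a 4.2-fold higher number (0.62 log units; beyond the scatter) from compound 3 to compound 4, 12-fold (1.06 log units) apart, beyond the scatter of two such steps. The same four compounds can be read through the other change, 2-chlorophenyl in place of 4-nitrophenyl, which gives a 3.1-fold higher number from compound 2 to compound 4 (0.49 log units; beyond the scatter) once piperidin-1-yl is present, and that also runs against its partner step: the same change on two cores in this assay, a 3.7-fold lower number (0.57 log units; beyond the scatter) from compound 1 to compound 3 and a 3.1-fold higher number (0.49 log units; beyond the scatter) from compound 2 to compound 4, 12-fold (1.06 log units) apart, beyond the scatter of two such steps. Within these four compounds, then, the effect of each change depends on the group at the other place, so a step measured on one core is a poor guide to the same step on another, but this does not show why the two places interact, or whether the reversal extends beyond this one pair of amines and this one pair of aromatic groups.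

The compounds shown leave open whether another amine, such as morpholine or dimethylamine, attached through the same carbon would follow the trend seen with 4-nitrophenyl or the one seen with 2-chlorophenyl. They also leave open how a plain phenyl group would behave with diethylamino and with piperidin-1-yl, which would show whether the reversal is tied to these two aromatic groups.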